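The source may report more compounds than this note shows. Statements on the series, on what has been measured and on what is new or still open speak of the compounds shown alone.

In a functional assay on UACC-62 cells (Homo sapiens) for antiproliferative activity, read by sulforhodamine B assay, with a stated time of 48 h (a lower number here means a stronger inhibitor of growth, a higher number a weaker inhibitor of growth), compound 2 `Nc1nn(C(=O)Nc2ccc(Cc3ccccc3)cc2)c2ccc(Cl)cc12` gives 41.2 nM, the lower of the two numbers at hand; compound 1 `Nc1nn(C(=O)Nc2ccc(Cc3ccccc3)cc2)c2ccccc12` gives 353 nM. Within the data shown here, the only measured step, an 8.6-fold lower number from compound 1 to compound 2 (0.93 log units; beyond the scatter), came from chloro in place of hydrogen on an aromatic carbon. Compound 3 `Nc1ccc2c(c1)c(N)nn2C(=O)Nc1ccc(Cc2ccccc2)cc1` carries the change (amino in place of chloro on an aromatic carbon), so the chloro that accompanied that step is gone and an amino stands in its place. Among the measured compounds shown here, no measured step involves an amino, so the expectation rests on that single step alone. The number for compound 3 is therefore expected to move back up, by an estimated 5.3-fold higher number from compound 2 to compound 3 (0.73 log units; beyond the scatter). Compound 3 is estimated at 220 nM, within a range from 60 nM to 800 nM.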

Compound 3, concentration for 50% growth inhibition: 2900 nM
Estimate against measurement, compound 3: 13-fold (1.12 log units) below; the whole stated range lies below it.
By their numbers in this assay, from the lowest: compound 2; then compound 1; then compound 3.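

In this assay amino in place of chloro brings a 70-fold higher number from compound 2 to compound 3 (1.85 log units; beyond the scatter) and amino in place of hydrogen brings an 8.2-fold higher number from compound 1 to compound 3 (0.91 log units; beyond the scatter) so amino does more than undo the gain seen with chloro. At this aromatic carbon, chloro and amino thus fall on opposite sides of hydrogen. Nothing measured here explains this difference. The compounds shown leave open where other groups at this carbon, such as fluoro, methoxy or an acetamide, would fall relative to chloro and amino, and whether the same order would hold elsewhere on this ring.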